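The source may report more compounds than this note shows. Statements on the series, on what has been measured and on what is new or still open speak of the compounds shown alone.

Measured in a functional assay on HL-60 cells (Homo sapiens) for cytotoxicity, read by MTT assay, with a stated time of 24 h; on this read-out lower numbers stand for stronger inhibition and higher numbers for weaker inhibition:
compound 1 `Brc1ccc(Oc2cc(Br)cc(Br)c2OCCCCCN2CCN(c3ccccc3)CC2)c(Br)c1`: 41.6 ug/mL
compound 2 `CC(=O)Oc1c(Br)cc(Br)cc1Oc1ccc(Br)cc1Br`: 29.9 ug/mL

Compound 2 at 29.9 ug/mL stands within the usual scatter of compound 1 at 41.6 ug/mL, so the two numbers cannot be told apart. Compound 3 `C=CCOc1c(Br)cc(Br)cc1Oc1ccc(Br)cc1Br` carries allyl in place of acetyl on an oxygen on an aromatic ring. Among the measured compounds shown here, no measured pair shows this change, so the data give no direct guide to it. The expectation in this assay is no shift beyond the scatter, with an estimated 1.0-fold higher number from compound 2 to compound 3 (0.00 log units; within the scatter). The estimate for compound 3 is 30 ug/mL, with an expected range of 13 ug/mL to 65 ug/mL.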

Compound 3, half-maximal inhibitory concentration: 27.9 ug/mL
Compound 3: the middle estimate sits 1.1-fold (0.03 log units) above what was measured; the range from low to high includes it.
By their numbers in this assay, from the lowest: compounds 3, 2 and 1 (each within the scatter of the next).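

In this assay, the step from acetoxy to allyloxy on an oxygen on an aromatic ring is a 1.1-fold lower number from compound 2 to compound 3 (0.03 log units; within the scatter). At this position, therefore, the number does not separate the two groups, although the acetyl carries a hydrogen-bond acceptor and the allyl carries none. Nothing measured on these compounds bears on why the two read alike.

Still open, as far as these compounds go, is whether a free hydroxyl, or a chain ending in a carboxylic acid, on this oxygen would move the number beyond the scatter. From the compounds shown here alone, whether the same holds on any other cell line also remains open.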